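The source may hold more compounds than are shown below. What is called first, only, known or untested is meant among the compounds shown, and "the series" means these compounds.

Measured so far:
- compound 1, `O=c1cc(N2CCN(CC3CCC(NS(=O)(=O)c4ccccc4)CC3)CC2)sc2c([N+](=O)[O-])cc(C(F)(F)F)cc12`: 90.8%
- compound 2, `O=C(OC1CCC(CN2CCN(c3cc(=O)c4cc(C(F)(F)F)cc([N+](=O)[O-])c4s3)CC2)CC1)c1ccc(F)cc1`: 3%

In an ADME assay on cells (Hepatocyte, Homo sapiens) for metabolic stability, with a stated time of 30 min (a lower number here means that less of the compound is left, a higher number that more of the compound is left), compound 1 stands highest of the two numbers, and its nearest neighbour is compound 2, which lies well beyond the scatter below it. Among the compounds with values here, the only step between measured compounds that differ in one place, a number 87.8 percentage points lower from compound 1 to compound 2 (beyond the scatter), shows how much the exchange of the (phenylsulfonyl)amino group for an ester on that saturated ring carbon moves the read-out.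

Compound 3, `O=C(OC1CCC(CN2CCN(c3cc(=O)c4cc(C(F)(F)F)cc([N+](=O)[O-])c4s3)CC2)CC1)c1cccs1`, has not been measured yet. It differs from compound 1 as follows: ((thiophen-2-yl)carbonyl)oxy in place of (phenylsulfonyl)amino on a saturated ring carbon. This change closely resembles the step from compound 1 to compound 2, since in both a ((aryl)carbonyl)oxy group takes the place of the (phenylsulfonyl)amino group. Given a number 87.8 percentage points lower from compound 1 to compound 2 (beyond the scatter), a large downward step of similar size is expected here, a number 84.8 percentage points lower from compound 1 to compound 3 (beyond the scatter). For compound 3 the estimate in this assay is 6%, with a range of 1% to 25%.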

Compound 3, percent of the compound remaining: 2.2%
Estimate against measurement, compound 3: 3.8 percentage points above, and the stated range covers the measured number.
By their numbers in this assay, from the lowest: compounds 3 and 2 (each within the scatter of the next); then compound 1.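

In this assay, a second ester repeats the large fall seen with the first: ((thiophen-2-yl)carbonyl)oxy in place of (phenylsulfonyl)amino on the saturated ring carbon gives a number 88.6 percentage points lower from compound 1 to compound 3 (beyond the scatter). Thiophen-2-yl in place of 4-fluorophenyl on the carbonyl carbon gives a number 0.8 percentage points lower from compound 2 to compound 3 (within the scatter), so in these compounds the exchange of one aryl group for the other leaves the number unmoved. Nothing measured here bears on why both esters stand so far below compound 1.

The compounds shown leave open whether the ester link or the aryl group sets the number, which a benzamide or an ether at this carbon could help to separate. They also leave open whether the (phenylsulfonyl)amino group would keep its high number with thiophen-2-yl or 4-fluorophenyl on the sulfonyl.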